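The source may hold more compounds than are shown below. What is called first, only, known or untested is meant among the compounds shown, and "the series" means these compounds.

The compounds share one core, seen in compound 1 `NC(=O)c1ccc2[nH]c(-c3ccc(OCCCN4CCCCC4)cc3)nc2c1`, in compound 2 `NC(=O)c1ccc2[nH]c(-c3ccc(OCC4CCCNC4)cc3)nc2c1` and in the not yet measured compound 3 `NC(=O)c1ccc2[nH]c(-c3ccc(OCC4CCCN(Cc5ccccc5)C4)cc3)nc2c1`. In a physicochemical assay for solubility, with a stated time of 3 days, at pH 2 (a lower number here means a less soluble compound, a higher number a more soluble compound), compound 1 reaches only a limit of the assay, > 400000 nM, and not a number. For compound 2 this assay gives "not determined" (no result reported), so no single number places it. Going by the values given here, the only anchor among the values shown is the limit of > 400000 nM in this assay, at which 1 of the 2 values shown sits. Compound 3 differs from compound 2 in one place: benzyl in place of hydrogen on an amine nitrogen in a ring. With no measured pair of this kind, the step from compound 2 to compound 3 in this assay cannot be sized from the numbers; a shift beyond the usual scatter in either direction would not be surprising, but nothing shown here points one way. Compound 3 is expected to come out near 200000 nM, within a range from 50000 nM to 400000 nM.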

Compound 3, solubility: > 400000 nM
Compound 3: no number, only a limit; the forecaster's own chance of this, stated with the estimate: 40%; middle value at least 2.0-fold (0.30 log units) from the limit.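

The step from compound 2 to compound 3 cannot be read in this assay, as compound 2 has no number there. Compound 3 gives > 400000 nM, a limit and not a number. The compounds shown leave open how benzyl in place of hydrogen changes solubility, with the values resting on one limit: the limit of > 400000 nM in this assay, at which 2 of the 3 values shown sit.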